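Swapping tert-Butyl for Chloro on the Benzyl Arm

This account rests on a few compounds, and the source may have more. Where it says the series, first, only, none or still open, it means among the compounds named here.

Measured compounds:
compound 1 `CC(C)(C)c1ccc(CNCCCNS(=O)(=O)c2cc(C(F)(F)F)cc(C(F)(F)F)c2)cc1`: 2000 nM
compound 2 `O=S(=O)(NCCCNCc1ccc(Cl)c(Cl)c1)c1cc(C(F)(F)F)cc(C(F)(F)F)c1`: 4700 nM
compound 3 `O=S(=O)(NCCCNCc1ccc(-c2ccccc2)cc1)c1cc(C(F)(F)F)cc(C(F)(F)F)c1`: 2300 nM

All three compounds share one core and differ only in the group carried on the benzyl arm. In a functional assay on HT-29 cells (Homo sapiens) for inhibition, read by MTT assay, with a stated time of 72 h (a higher number here means a weaker inhibitor of growth, a lower number a stronger inhibitor of growth), compound 1 gives 2000 nM, the lowest number of the three. Compound 3 lies within the scatter of it (a 1.2-fold higher number from compound 1 to compound 3 (0.06 log units; within the scatter)), while compound 2 gives a higher number (a 2.4-fold higher number from compound 1 to compound 2 (0.37 log units; beyond the scatter)).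

Compound 4 `O=S(=O)(NCCCNCc1ccc(Cl)cc1)c1cc(C(F)(F)F)cc(C(F)(F)F)c1` is the next step from compound 1. The change is chloro in place of tert-butyl on an aromatic carbon. Going by the values given here, two measured steps bear on it. The step from compound 1 to compound 3 shows that replacing tert-butyl by another bulky group hardly moved this assay . The step from compound 1 to compound 2, which puts chlorines on the ring in place of tert-butyl, raised the number modestly. A single chloro is closer in kind to that second step, so compound 4 is expected to give a modestly higher number, roughly a 2.0-fold higher number from compound 1 to compound 4 (0.30 log units; within the scatter). Compound 4 is estimated at 4000 nM, with a likely range from 1800 nM to 9000 nM.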

Compound 4, concentration for 50% growth inhibition: 2800 nM
For compound 4 the middle estimate is 1.4-fold (0.15 log units) above the measured one, and the stated range covers the measured number.
By their numbers in this assay, from the lowest: compounds 1, 3, 4 and 2 (each within the scatter of the next, the first and the last beyond it).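

Replacing the four carbons of tert-butyl with a single chlorine gives no change that can be told from the scatter in this assay (a 1.4-fold higher number from compound 1 to compound 4 (0.15 log units; within the scatter)), so the bulk of tert-butyl is not required on this aromatic carbon for the growth inhibition seen here. Chloro in place of phenyl likewise stays within the scatter (a 1.2-fold higher number from compound 3 to compound 4 (0.09 log units; within the scatter)), as does removing the second chlorine (a 1.7-fold lower number from compound 2 to compound 4 (0.22 log units; within the scatter)). The one step beyond the scatter, a 2.4-fold higher number from compound 1 to compound 2 (0.37 log units; beyond the scatter), therefore divides into two smaller steps through compound 4, each within the scatter, and the differences among these compounds remain small.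

No available measurement gives a reason for these numbers. Going by these compounds, whether an amine or a carboxylic acid on this aromatic carbon would shift the number beyond the scatter remains open.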